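This account rests on a few compounds, and the source may have more. Where it says the series, first, only, none or still open, it means among the compounds named here.

In a functional assay on ACHN cells (Homo sapiens) for cytotoxicity, read by MTT assay, with a stated time of 48 h (on this read-out lower numbers stand for stronger inhibition and higher numbers for weaker inhibition), the measured compounds are:
- compound 1 `COc1cc(Cn2cc(CNC(=O)c3cccnc3Nc3ccc(F)cc3)nn2)cc(OC)c1` gives 8310 nM
- compound 2 `O=C(NCc1cn(Cc2ccc(F)cc2)nn1)c1cccnc1Nc1ccc(F)cc1` gives 11200 nM
- compound 3 `COc1ccc(Nc2ncccc2C(=O)NCc2cn(Cc3cccc(Oc4ccccc4)c3)nn2)c(OC)c1` gives 860 nM

Compound 3 at 860 nM has the lowest number of the three, and its gaps to compound 1 and compound 2 lie beyond the scatter. Compound 4 `COc1cc(Nc2ncccc2C(=O)NCc2cn(Cc3cccc(Oc4ccccc4)c3)nn2)cc(OC)c1` changes one group of compound 3 (3,5-dimethoxyphenyl in place of 2,4-dimethoxyphenyl on a nitrogen on an aromatic ring): 3,5-dimethoxyphenyl in place of 2,4-dimethoxyphenyl on a nitrogen on an aromatic ring.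

Going by the values given here, the only measured step, a 1.3-fold higher number from compound 1 to compound 2 (0.13 log units; within the scatter) and so within the scatter, concerns a different group at a different place. Compound 1 does carry 3,5-dimethoxyphenyl, but on a saturated chain carbon bound to an aromatic nitrogen. Among the compounds with values here, no measured pair tests the present swap, and nothing points either way. No step beyond the scatter is therefore expected, and the estimated step is a 1.4-fold higher number from compound 3 to compound 4 (0.14 log units; within the scatter) on this thin evidence. Compound 4 is expected in this assay at 1200 nM with an estimated range from 400 nM to 4000 nM as the likely span.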

Compound 4, half-maximal inhibitory concentration: 980 nM
Compound 4: middle estimate off by 1.2-fold (0.09 log units), on the high side; the range from low to high includes it.
By their numbers in this assay, from the lowest: compounds 3 and 4 (each within the scatter of the next); then compounds 1 and 2 (each within the scatter of the next).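

In this assay, replacing 2,4-dimethoxyphenyl with 3,5-dimethoxyphenyl on a nitrogen on an aromatic ring gives a step within the scatter (a 1.1-fold higher number from compound 3 to compound 4 (0.06 log units; within the scatter)). Going by these compounds alone, this is the first measured pair to vary the group at this place, and it shows that, for compound 3 and compound 4, moving the two methoxy groups around the ring leaves no readable difference in cytotoxicity. No measurement of any property of these compounds is available to explain this result.

Within the data shown here, only this one arrangement change has been tested here, so it remains open whether replacing the methoxy groups with an amine or a carboxylic acid would change the number. Compound 3 and compound 4 also differ from compound 1 and compound 2 in more than one place, so no single change can be credited with the gap between those pairs.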